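Isopropyl to 1-Hydroxyethyl on a Shorter Alkyl Chain

The compounds below may be only part of what the source reports. "The series", "measured", "known", "first", "only" and "open" are said of these compounds alone.

Three amino-alcohols have been measured in a functional assay on HBL-100 cells (Homo sapiens) for antiproliferative activity, read by sulforhodamine B assay, with a stated time of 48 h; on this read-out higher numbers stand for weaker inhibition of growth and lower numbers for stronger inhibition of growth. Compound 2 `CCCCCCCCCCCCCCC[C@@H](O)[C@@H](N)C(C)C` gives 4900 nM in this assay. Compound 1 `CCCCCCCCCCCCCCC[C@@H](O)[C@@H](N)[C@@H](C)O` differs from compound 2 by the change (1-hydroxyethyl in place of isopropyl on a saturated chain carbon bound to an amine nitrogen and a saturated chain carbon); in this assay compound 1 gives 21000 nM, and the step is a 4.3-fold higher number from compound 2 to compound 1 (0.63 log units; beyond the scatter). Compound 3 `CCCCCCCCC[C@@H](O)[C@@H](N)C(C)C` keeps the isopropyl group but has a shorter chain, and it gives 14000 nM in this assay; the step is a 2.9-fold higher number from compound 2 to compound 3 (0.46 log units; beyond the scatter). The numbers for compound 3 and compound 1 lie within the usual scatter of each other, so nothing can be said about which of these two inhibits growth more strongly.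

Compound 4 `CCCCCCCCC[C@@H](O)[C@@H](N)[C@@H](C)O` has not yet been measured. It is made from compound 3 by the change (1-hydroxyethyl in place of isopropyl on a saturated chain carbon bound to an amine nitrogen and a saturated chain carbon). This is the same change that leads from compound 2 to compound 1, and the place is described in the same words, so it is the same kind of change on a different core. The two cores differ by hydrogen in place of hexyl on a saturated chain carbon, ten or more bonds along the chain from an oxygen on a saturated carbon.

For the measured compounds named here, the step from compound 3 to compound 4 is expected to be a 3.6-fold higher number from compound 3 to compound 4 (0.55 log units; beyond the scatter), set beside the measured step of a 4.3-fold higher number from compound 2 to compound 1 (0.63 log units; beyond the scatter), which is the only instance of this change with a number so far; a somewhat smaller step is allowed for, since the two measured numbers near compound 3 already lie close together. Compound 4 is therefore expected to give 50000 nM in this assay, with a likely range from 20000 nM to 120000 nM.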

Compound 4, concentration for 50% growth inhibition: 13000 nM
The estimate for compound 4 lay 3.8-fold (0.59 log units) above the measured number; measured number outside the range, below it.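

On the shorter chain, putting 1-hydroxyethyl in place of isopropyl does not repeat what it did on the longer chain. In this assay the new step is a 1.1-fold lower number from compound 3 to compound 4 (0.03 log units; within the scatter), and it does not match the earlier one: the same change on two cores in this assay, a 4.3-fold higher number (0.63 log units; beyond the scatter) from compound 2 to compound 1 and a 1.1-fold lower number (0.03 log units; within the scatter) from compound 3 to compound 4, 4.6-fold (0.66 log units) apart, beyond the scatter of two such steps. The same mismatch appears when the chain change is read with 1-hydroxyethyl kept in place, where the step is a 1.6-fold lower number from compound 1 to compound 4 (0.21 log units; within the scatter), and this differs from the step with isopropyl kept in place: the same change on two cores in this assay, a 2.9-fold higher number (0.46 log units; beyond the scatter) from compound 2 to compound 3 and a 1.6-fold lower number (0.21 log units; within the scatter) from compound 1 to compound 4, 4.6-fold (0.66 log units) apart, beyond the scatter of two such steps. So in these four compounds the size of the step depends on the core that carries it, and a step measured on one core was a poor guide to the other, although a single pair of cores cannot show how general this is or why it happens.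

The compounds shown leave open how the step would look on a longer chain or on a chain of a length lying between the two seen here. They also leave open whether another group at the same place, such as an aminoethyl group or a carboxylic acid, would depend on the chain in the same way.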